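The source may hold more compounds than are shown below. What is called first, only, known or untested is meant among the compounds shown, and "the series" means these compounds.

Measured so far:
compound 1, `CC(C)c1cccc(C(C)C)c1NC(=O)NC(=O)Nc1c(C(C)C)cccc1C(C)C` — > 5000 nM
compound 2, `CCN(CC)C(=O)NC(=O)Nc1c(C(C)C)cccc1C(C)C` — > 5000 nM

Both compounds share a core carrying two isopropyl groups on a phenyl ring joined to a urea-type chain, and both were tested in an assay on microsomes from intestine for inhibition of acyl-CoA:cholesterol acyltransferase (Oryctolagus cuniculus); on this read-out lower numbers stand for stronger inhibition and higher numbers for weaker inhibition. In this assay compound 1 gives > 5000 nM, which is a limit of the assay rather than a number. In this assay compound 2 gives > 5000 nM, again a limit and not a number. Within the data shown here, compound 2 therefore stands where every value so far stands: the limit of > 5000 nM in this assay, at which 2 of the 2 values shown sit. Nothing measured here separates one compound from the other.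

Compound 3, `CCCCN(CCCC)C(=O)NC(=O)Nc1c(C(C)C)cccc1C(C)C`, has not yet been measured. It differs from compound 2 in one place: dibutylamino in place of diethylamino on a carbonyl carbon. Among the measured compounds shown here, with both measured values sitting at the limit, there is no measured step to say how a change at this carbonyl carbon moves the read-out. The step is expected to be a step that the limit leaves unreadable from compound 2 to compound 3, which lies within the usual scatter and points in no clear direction. Compound 3 is accordingly estimated at 6000 nM, with a range from 2500 nM to 20000 nM, and a further limit rather than a number is the likelier outcome.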

Compound 3, half-maximal inhibitory concentration: 250 nM
Compound 3: the middle estimate sits 24-fold (1.38 log units) above what was measured; measured number outside the range, below it.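

In this assay the group on the carbonyl carbon proves able to move the read-out: dibutylamino in place of diethylamino gives an at least 20-fold lower number from compound 2 to compound 3 (1.30 log units; beyond the scatter) and brings a measured number into view. The earlier compounds shown here could not show this, since neither gave a number and nothing separated them, whereas this single change of amine group now separates two compounds that share the rest of their structure. Compound 3 is the only compound shown with a number, while the other two remain at a limit: the limit of > 5000 nM in this assay, at which 2 of the 3 values shown sit.

What the compounds leave open is how the read-out follows the size of this group, since one step between diethylamino and dibutylamino gives only two points, and one of those is a limit rather than a number. Dipropylamino would show whether the change sets in gradually or abruptly, dihexylamino whether still longer chains carry it further, and butylamino, with a single chain and the amine hydrogen kept, whether both butyl chains are needed.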